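Branching the Hydroxyalkyl Arm on a Shared Core

The source may report more compounds than this note shows. Statements on the series, on what has been measured and on what is new or still open speak of the compounds shown alone.

Compound 1 `CC(C)(C)c1cn(CCNc2nonc2/C(=N/O)Nc2ccc(F)c(Br)c2)nn1`: 132 nM
Compound 2 `OCCc1cn(CCNc2nonc2/C(=N/O)Nc2ccc(F)c(Br)c2)nn1`: 247 nM

Two measured compounds share one core and differ only in the group carried on an aromatic carbon of a five-membered aromatic ring with 3 nitrogen. In an assay on isolated protein for inhibition of Indoleamine 2,3-dioxygenase 1 (Homo sapiens) (on this read-out higher numbers stand for weaker inhibition and lower numbers for stronger inhibition), compound 1 gives 132 nM, while compound 2 gives 247 nM. Among the compounds with values here, the single step between them, a 1.9-fold higher number from compound 1 to compound 2 (0.27 log units; within the scatter), replaces tert-butyl with 2-hydroxyethyl, and its size lies inside the usual scatter of repeated measurements. Within the data shown here, compound 2 therefore holds the higher of the two numbers, yet with compound 1 as its only neighbour and that gap within the scatter, nothing can be said about which compound inhibits more strongly.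

Compound 3 `CCC(C)(O)c1cn(CCNc2nonc2/C(=N/O)Nc2ccc(F)c(Br)c2)nn1` has not been measured. Its change from compound 2 is 1-hydroxy-1-methylpropyl in place of 2-hydroxyethyl on an aromatic carbon. Among the measured compounds shown here, the only measured step that bears on this change is a 1.9-fold higher number from compound 1 to compound 2 (0.27 log units; within the scatter), which swapped a branched hydrocarbon group for a hydroxyl-bearing one with little effect. Compound 3 keeps a hydroxyl while adding carbon branching, so the step of a 1.4-fold lower number from compound 2 to compound 3 (0.14 log units; within the scatter) is expected to stay small, perhaps a slightly lower number. Compound 3 is estimated at 180 nM, within 70 nM to 450 nM.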

Compound 3, half-maximal inhibitory concentration: 53 nM
Estimate against measurement, compound 3: 3.4-fold (0.53 log units) above; the measured number lies below the stated range.
By their numbers in this assay, from the lowest: compound 3; then compounds 1 and 2 (each within the scatter of the next).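

On an aromatic carbon of this five-membered ring, the choice of group can shift the number beyond the scatter in this assay: a 4.7-fold lower number from compound 2 to compound 3 (0.67 log units; beyond the scatter) follows when 1-hydroxy-1-methylpropyl replaces 2-hydroxyethyl, a difference of two heavy carbon atoms with the same hydrogen-bond donor and acceptor counts. Replacing tert-butyl with 1-hydroxy-1-methylpropyl also gives a 2.5-fold lower number from compound 1 to compound 3 (0.40 log units; beyond the scatter), so compound 3 is the strongest inhibitor of the three, while the branched hydrocarbon group of compound 1 and the unbranched hydroxyl-bearing group of compound 2 remain within the scatter of each other. Nothing presented here explains why the larger hydroxyl-bearing group gives the lowest number.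

Compound 3 differs from compound 2 in both branching and chain size, and from compound 1 in carrying a hydroxyl, so these compounds cannot show which feature matters or whether the two must occur together. A longer unbranched chain ending in a hydroxyl, or a branched group carrying an amine in place of the hydroxyl, would help separate those possibilities.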